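The compounds below may be only part of what the source reports. "The series", "measured", "known", "first", "only" and "open" are said of these compounds alone.

In a functional assay on NCI-H727 cells (Homo sapiens) for antiproliferative activity, with a stated time of 48 h (a higher number here means a weaker inhibitor, a lower number a stronger inhibitor), compound 1 (`CCN(CC)c1ccc(-c2cccc(Cl)c2)nn1`) gives > 25000 nM, which is a limit and not a number. Compound 2 (`CCN(CC)c1ccc(-c2cccc(C(F)(F)F)c2)nn1`) gives > 25000 nM, likewise a limit. Compound 3 (`CCOC(=O)c1cccc(-c2ccc(N(CC)CC)nn2)c1`) carries ethoxycarbonyl in place of trifluoromethyl on an aromatic carbon. Within the data shown here, the only measured step that bears on this change is a step that the two limits leave unreadable from compound 1 to compound 2, and the evidence amounts to the limit of > 25000 nM in this assay, at which 2 of the 2 values shown sit, so no size can be carried over. In this assay, no clear step in either direction is expected, and compound 3 is expected to remain near the limit. The expected change is a number no higher from compound 2 to compound 3 (the limit leaves the size open). For compound 3 the estimated value is 25000 nM, with an expected range of 10000 nM to 50000 nM.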

Compound 3, half-maximal inhibitory concentration: 30000 nM
Beside the measured number, compound 3's estimate is 1.2-fold (0.08 log units) below it, and the stated range covers the measured number.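

No step to compound 3 can be read from compound 1 or compound 2 in this assay, as both earlier values are limits: the limit of > 25000 nM in this assay, at which 2 of the 3 values shown sit.

The compounds shown leave open whether chloro, trifluoromethyl and ethoxycarbonyl differ at all in this activity.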